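Fluoro for hydrogen on an inactive pair

The source may hold more compounds than are shown below. What is called first, only, known or untested is meant among the compounds shown, and "the series" means these compounds.

Compound 1 `O=[N+]([O-])c1ccc(O)c(/C=N/c2ccc(OCc3ccccc3)cc2)c1`: > 200000 nM.
Compound 2 `Oc1ccccc1/C=N/c1ccc(OCc2ccccc2)cc1`: > 200000 nM.

In a functional assay, with a stated time of 30 min (a higher number here means a weaker inhibitor, a lower number a stronger inhibitor), compound 1 reads only a limit of the assay. Compound 2 likewise reads only a limit of the assay. The step that the two limits leave unreadable from compound 1 to compound 2 therefore cannot be read, because of the limit of > 200000 nM in this assay, at which 2 of the 2 values shown sit. Compound 2 stands at that limit, with no number beneath it.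

Compound 3 `Oc1ccc(F)cc1/C=N/c1ccc(OCc2ccccc2)cc1` differs from compound 2 by fluoro in place of hydrogen on an aromatic carbon. Within the data shown here, no measured step bears on this change; the only step known is unreadable. In this assay the expected step is a step that the limit leaves unreadable from compound 2 to compound 3, most likely ending again at a limit. Compound 3 is expected at 250000 nM, within 100000 nM to 600000 nM.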

Compound 3, half-maximal inhibitory concentration: > 200000 nM
Compound 3 ended at the assay's limit (the forecaster's own chance of this, stated with the estimate: 85%); the middle value does not contradict the limit.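

No step among compound 1, compound 2 and compound 3 can be read, because each reads only a limit of the assay: the limit of > 200000 nM in this assay, at which 3 of the 3 values shown sit.

The compounds shown leave open whether any change to the shared core gives a measurable value in this assay.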